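The source may hold more compounds than are shown below. What is called first, only, known or untested is meant among the compounds shown, and "the series" means these compounds.

Compound 1, `Cc1cc(NC(=O)Nc2cccc(Cl)c2)c2ccccc2n1`: 800 nM
Compound 2, `Cc1cc(NC(=O)Nc2ccc(F)cc2)c2ccccc2n1`: 3700 nM
Compound 3, `Cc1cc(NC(=O)Nc2ccc(F)cc2F)c2ccccc2n1`: 3000 nM

These three share one core and differ only in the aryl group on the urea nitrogen. In a physicochemical assay for solubility, at pH 7.4 (a lower number here means a less soluble compound, a higher number a more soluble compound), compound 2 stands highest of the three numbers. The nearest of the other numbers lies within the scatter: a 1.2-fold lower number from compound 2 to compound 3 (0.09 log units; within the scatter). The furthest lies beyond it: a 4.6-fold higher number from compound 1 to compound 2 (0.67 log units; beyond the scatter).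

Compound 4, `Cc1cc(NC(=O)Nc2ccc(C(N)=O)cc2)c2ccccc2n1`, has not yet been measured. It differs from compound 2 in one place: carbamoyl in place of fluoro on an aromatic carbon.

Neither measured step is of this kind. The step into compound 3 added a fluoro and moved the number within the scatter; the step into compound 2 exchanged one halogen pattern for another and gave a modest rise. The data hold no exchange of a halogen for a carbamoyl, so the expectation for compound 4 rests on little beyond the general spread of the three numbers. The estimate for compound 4 in this assay is a modest rise over compound 2, of the order of a 1.6-fold higher number from compound 2 to compound 4 (0.21 log units; within the scatter). Compound 4 is therefore expected to give about 6000 nM, within a range of 2500 nM to 15000 nM.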

Compound 4, solubility: 900 nM
For compound 4 the middle estimate is 6.7-fold (0.82 log units) above the measured one; the measured number lies below the stated range.
By their numbers in this assay, from the lowest: compounds 1 and 4 (each within the scatter of the next); then compounds 3 and 2 (each within the scatter of the next).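

In this assay the exchange of fluoro for carbamoyl on the aromatic carbon para to a large group gives a 4.1-fold lower number from compound 2 to compound 4 (0.61 log units; beyond the scatter) and is the only downward step beyond the scatter among those shown. The earlier steps shown here showed a rise beyond the scatter in a 4.6-fold higher number from compound 1 to compound 2 (0.67 log units; beyond the scatter) and a move within the scatter when fluoro replaced hydrogen in a 1.2-fold lower number from compound 2 to compound 3 (0.09 log units; within the scatter) so neither showed that a single exchange at this position could take away the high number of compound 2. Here the entering carbamoyl brings a hydrogen-bond donor and a hydrogen-bond acceptor where the leaving fluoro has neither, but nothing in the information available explains the fall in the number.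

From the compounds shown here alone, with a single exchange of this kind, it remains open whether the fall belongs to the carbamoyl itself or would also appear with an amine, a carboxylic acid or a nitrile on the same aromatic carbon. Going by these compounds, it is equally open whether a longer chain ending in a carbamoyl, or an N-methyl carbamoyl, would give a number closer to that of compound 2.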